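The source may report more compounds than this note shows. Statements on the series, on what has been measured and on what is new or still open speak of the compounds shown alone.

Compound 1, with the structure `CN(Cc1ccc2nccn2c1)c1nnc(-c2ccccc2)o1`, in an assay on isolated protein for inhibition of tyrosine-protein kinase receptor UFO (Homo sapiens), read by LC-MS (on this read-out higher numbers stand for weaker inhibition and lower numbers for stronger inhibition), gives > 100000 nM, which is a limit of the assay rather than a number. Compound 2, `CN(Cc1ccc2nccn2c1)c1nnc(-c2ccc(C3CC3)cc2)o1`, in this assay gives 20000 nM. Compound 3, `Cc1ncccc1-c1ccc(-c2nnc(N(C)Cc3ccc4nccn4c3)o2)cc1`, in this assay gives 6310 nM.

Compound 3 carries the lowest of the two numbers shown; its nearest neighbour is compound 2, with a 3.2-fold lower number from compound 2 to compound 3 (0.50 log units; beyond the scatter). Compound 1 sits at the limit of > 100000 nM in this assay, at which 1 of the 3 values shown sits, and so cannot be placed exactly, but the step of an at least 15-fold lower number from compound 1 to compound 3 (1.19 log units; beyond the scatter) is large in any case. Compound 4, `Cc1nn(C)c(C)c1-c1ccc(-c2nnc(N(C)Cc3ccc4nccn4c3)o2)cc1`, is not yet measured. It differs from compound 3 by 1,3,5-trimethyl-1H-pyrazol-4-yl in place of 2-methylpyridin-3-yl on an aromatic carbon. The two measured steps that touch this position are an at least 15-fold lower number from compound 1 to compound 3 (1.19 log units; beyond the scatter) and a 3.2-fold lower number from compound 2 to compound 3 (0.50 log units; beyond the scatter); both show that a ring at this place lowers the number, and compound 4 keeps a ring there. Exchanging one small aromatic ring for another is therefore expected to give, at most, a step around the scatter, a 1.1-fold lower number from compound 3 to compound 4 (0.02 log units; within the scatter). Compound 4 is expected to give about 6000 nM, likely between 2000 nM and 20000 nM.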

Compound 4, half-maximal inhibitory concentration: 1260 nM
Estimate against measurement, compound 4: 4.8-fold (0.68 log units) above, outside the stated range (below it).
By their numbers in this assay, from the lowest: compound 4; then compound 3; then compound 2. At a limit, above all of these: compound 1.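

In this assay, among the compounds shown here, the earlier compounds showed only that a ring at this place lowers the number, whereas replacing 2-methylpyridin-3-yl with 1,3,5-trimethyl-1H-pyrazol-4-yl shows that the choice of ring matters too, with a 5.0-fold lower number from compound 3 to compound 4 (0.70 log units; beyond the scatter). The same ring also does better than the smaller groups at this aromatic carbon, with a 16-fold lower number from compound 2 to compound 4 (1.20 log units; beyond the scatter) against cyclopropyl and an at least 79-fold lower number from compound 1 to compound 4 (1.89 log units; beyond the scatter) against hydrogen. Compound 1 gives only a limit and not a number: the limit of > 100000 nM in this assay, at which 1 of the 4 values shown sits.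

Whether the lower number goes with the five-membered ring itself or with its methyl groups stays open; the two change together in the compounds shown. Also open, going by these compounds, is how a pyrazol-4-yl without methyl groups, or a ring carrying an amine or a carboxylic acid, would behave at this place.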